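The compounds below may be only part of what the source reports. "The series", "measured", "known", "first", "only" and "open" are said of these compounds alone.

Compound 1 `C[C@]1(C(=O)N2CC[C@](c3ccc(C(F)(C(F)(F)F)C(F)(F)F)cc3)(S(=O)(=O)c3ccc(F)cc3)C2)CC[C@H](C(=O)O)CC1` and compound 2 `O=C(N1CC[C@](c2ccc(C(F)(C(F)(F)F)C(F)(F)F)cc2)(S(=O)(=O)c2ccc(F)cc2)C1)C12CCC(C(=O)O)(CC1)OC2` share one core and differ in the group on the amide carbonyl carbon. In an ADME assay on microsomes from liver (Mus musculus) for metabolic stability, with a stated time of 10 min (on this read-out higher numbers stand for a more stable compound and lower numbers for a less stable compound), compound 1 gives 95%. Compound 2 has no place on that scale, as the entry for compound 2 reads "not determined" (no result reported). The next molecule, compound 3 `O=C([C@H]1CC[C@H](c2nnn[nH]2)CC1)N1CC[C@](c2ccc(C(F)(C(F)(F)F)C(F)(F)F)cc2)(S(=O)(=O)c2ccc(F)cc2)C1`, has yet to be measured. It departs from compound 2 in one place, on a carbonyl carbon whose other neighbours are an amide-type nitrogen in a ring: a group of 11 heavy atoms (7 carbon, 4 nitrogen; one five-membered aromatic ring with 4 hetero atoms, one six-membered non-aromatic ring of carbon only) in place of a group of 11 heavy atoms (8 carbon, 3 oxygen; one six-membered non-aromatic ring of carbon only, one six-membered non-aromatic ring with 1 hetero atom), on a carbonyl carbon. The group that enters is 4-(1H-tetrazol-5-yl)cyclohexyl. For the measured compounds named here, with no measured step available, the only guide is compound 1 at 95%, so compound 3 is expected to land near that value, with no difference beyond the usual scatter in either direction. For compound 3 the estimate is 88%, with an expected range from 68% to 100%.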

Compound 3, percent of the compound remaining: 73%
Estimate against measurement, compound 3: 15 percentage points above; the range from low to high includes it.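

In this assay, the group on a carbonyl carbon whose other neighbours are an amide-type nitrogen in a ring now has a measured effect: 4-(1H-tetrazol-5-yl)cyclohexyl in place of 4-carboxy-1-methylcyclohexyl gives a number 22 percentage points lower from compound 1 to compound 3 (beyond the scatter) here. This position is therefore not indifferent to the group it carries, while any step involving compound 2 cannot be read, as compound 2 has no result. Nothing measured here accounts for the size of this step.

The change replaces the carboxylic acid with the tetrazole and also removes the methyl, so the compounds shown leave open which of these two parts matters. A compound with 4-carboxycyclohexyl on the same carbonyl carbon would tell them apart.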